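Sulfanyl substituents on the shared core and GES1 toxicity

This account rests on a few compounds, and the source may have more. Where it says the series, first, only, none or still open, it means among the compounds named here.

Compound 1 `Cc1cc(N2CC[C@@H](C)[C@@H](N(C)c3ncnc4[nH]ccc34)C2)n2ncnc2n1` is the parent with hydrogen at the site of variation. Going by the values given here, in a toxicity assay on GES1 cells (Homo sapiens) for inhibition, read by MTT assay, with a stated time of 72 h (a higher number here means a weaker inhibitor, a lower number a stronger inhibitor), compound 1 gives 57900 nM, the only actual number among the three values in hand. Compound 2 `C=CCSc1nc2nc(C)cc(N3CC[C@@H](C)[C@@H](N(C)c4ncnc5[nH]ccc45)C3)n2n1` carries allylsulfanyl on that aromatic carbon; in this assay compound 2 reaches only the limit > 100000 nM. Compound 3 `Cc1cc(N2CC[C@@H](C)[C@@H](N(C)c3ncnc4[nH]ccc34)C2)n2nc(SCc3ccccc3Br)nc2n1` carries (2-bromobenzyl)sulfanyl; in this assay compound 3 likewise sits at the limit > 100000 nM. Both steps from the parent run upward: an at least 1.7-fold higher number from compound 1 to compound 2 (0.23 log units; that floor lies within the scatter) and an at least 1.7-fold higher number from compound 1 to compound 3 (0.23 log units; that floor lies within the scatter), each floor lying within the scatter. Between the two sulfanyl compounds, a step that the two limits leave unreadable from compound 2 to compound 3. The limit of > 100000 nM in this assay, at which 2 of the 3 values shown sit, sets what can be read here.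

Compound 4 `Cc1cc(N2CC[C@@H](C)[C@@H](N(C)c3ncnc4[nH]ccc34)C2)n2nc(SCc3ccc(Br)cc3)nc2n1` is not yet measured. It differs from compound 1 by (4-bromobenzyl)sulfanyl in place of hydrogen on an aromatic carbon. The closest measured case is compound 3, whose limit > 100000 nM was reached with a bromobenzylsulfanyl group of the same kind, and both sulfanyl additions so far moved the reading to the limit. The expected step is a 2.6-fold higher number from compound 1 to compound 4 (0.41 log units; beyond the scatter), upward, most probably ending at the limit again. The estimate for compound 4 in this assay is 150000 nM, with a range from 60000 nM to 400000 nM.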

Compound 4, half-maximal inhibitory concentration: 55600 nM
The estimate for compound 4 lay 2.7-fold (0.43 log units) above the measured number, and the stated range ends above it.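

In this assay, a sulfanyl group on this aromatic carbon between two ring nitrogen atoms does not by itself bring the reading to the limit: (4-bromobenzyl)sulfanyl in place of hydrogen gives a 1.0-fold lower number from compound 1 to compound 4 (0.02 log units; within the scatter). Moving the bromine from the 2-bromobenzyl to the 4-bromobenzyl arrangement gives an at least 1.7-fold lower number from compound 3 to compound 4 (0.25 log units; that floor lies within the scatter), and replacing the vinyl end of the allyl group with 4-bromophenyl gives an at least 1.7-fold lower number from compound 2 to compound 4 (0.25 log units; that floor lies within the scatter). These two steps are only floors, so any dependence on the substituent's end group remains unproven: the limit of > 100000 nM in this assay, at which 2 of the 4 values shown sit.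

On these data alone, the true distance of compound 2 and compound 3 from compound 4 stays open, as both of their readings are limits. Also open, as far as these compounds go, is how a 3-bromobenzyl group, an aminomethyl group on the benzyl ring or a longer chain before the ring would read at this position.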